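The source may report more compounds than this note shows. Statements on the series, on what has been measured and on what is new or still open speak of the compounds shown alone.

Measured so far:
compound 1, `C=CCc1c(OC)nc2nc(C(=O)c3ccccc3)cn2c1C`: 10 mg/kg
compound 2, `CCc1c(OC)nc2nc(C(=O)c3ccccc3)cn2c1C`: 2 mg/kg

Both compounds were tested in a functional assay on the whole organism with Rattus norvegicus as the target; a lower number here means that less compound is needed, a higher number that more compound is needed for the effect. Within the data shown here, compound 2 gives the lowest of the two numbers; the only other measured compound is compound 1, and the two are separated by a 5.0-fold lower number from compound 1 to compound 2 (0.70 log units; beyond the scatter), a difference that lies beyond the usual scatter of the assay.

Compound 3, `CCCc1c(OC)nc2nc(C(=O)c3ccccc3)cn2c1C`, has not yet been measured. It differs from compound 2 by methyl in place of hydrogen on a saturated chain carbon, two bonds along the chain from an aromatic carbon. Put differently, the chain that is ethyl in compound 2 becomes propyl in compound 3, a lengthening of the same chain rather than a change of its terminal group.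

Among the measured compounds shown here, only one measured step bears on this chain, a 5.0-fold lower number from compound 1 to compound 2 (0.70 log units; beyond the scatter), and it came from exchanging vinyl for methyl, a change in kind rather than in length. It does not show how a longer saturated chain behaves, so it gives little direct guidance. With nothing pointing clearly either way, compound 3 is expected to stay close to compound 2, with perhaps a slight increase in the dose needed. The expected step of a 1.5-fold higher number from compound 2 to compound 3 (0.18 log units; within the scatter) is small and would lie within the scatter. Compound 3 is therefore estimated at 3 mg/kg, with a likely range from 1 mg/kg to 10 mg/kg.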

Compound 3, minimum effective dose: 5 mg/kg
The estimate for compound 3 lay 1.7-fold (0.22 log units) below the measured number, and the stated range covers the measured number.
By their numbers in this assay, from the lowest: compound 2; then compounds 3 and 1 (each within the scatter of the next).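

Lengthening the saturated chain from ethyl to propyl is not neutral in this assay: it gives a 2.5-fold higher number from compound 2 to compound 3 (0.40 log units; beyond the scatter), so the added methyl, two bonds along the chain from an aromatic carbon, raises the dose needed, and among these compounds, compound 2 with its ethyl chain needs the lowest dose. Among these compounds, this is the first direct reading of chain length at this position, whereas the earlier step exchanged vinyl for methyl and so changed the chain end in kind. The new comparison of the vinyl-ended chain with propyl, a 2.0-fold lower number from compound 1 to compound 3 (0.30 log units; within the scatter), stays within the scatter, so compound 1 and compound 3 cannot be told apart, and no measurement shown explains why the dose responds to these chains.

From the compounds shown here alone, with so few compounds, it remains open whether ethyl is a true optimum, since a plain methyl group at this place and a longer chain such as butyl would be needed to test the trend on both sides. Also open, going by these compounds, is how a chain ending in an amine or a carboxylic acid would fare in this whole-animal test.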